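Aryl replacement on the fused ring of compound 2

The compounds below may be only part of what the source reports. "The series", "measured", "known", "first", "only" and "open" are said of these compounds alone.

Compound 2 `COc1ccc(-c2cc([N+](=O)[O-])cc3cc(C(O)(c4ccc(C#N)cc4)c4cncn4C)oc23)cc1` gives 36 nM in a functional assay on QG-56 cells (Homo sapiens) for antiproliferative activity (on this read-out lower numbers stand for stronger inhibition and higher numbers for weaker inhibition), the lowest of the three numbers: compound 3 `Cn1cncc1C(O)(c1ccc(Cl)cc1)c1cc2cc([N+](=O)[O-])cc(-c3ccccc3)c2o1` gives 1890 nM and compound 1 `COc1ccc(C(O)(c2cc3cc([N+](=O)[O-])cc(-c4ccccc4)c3o2)c2cncn2C)cc1` gives 4970 nM. Compound 4 `Cc1cccc(-c2cc([N+](=O)[O-])cc3cc(C(O)(c4ccc(C#N)cc4)c4cncn4C)oc23)c1` differs from compound 2 by 3-methylphenyl in place of 4-methoxyphenyl on an aromatic carbon. Among the compounds with values here, the only single-point step among the measured compounds, a 2.6-fold lower number from compound 1 to compound 3 (0.42 log units; beyond the scatter), concerns a different part of the structure, so no measured step bears directly on the change toward compound 4. Within the data shown here, with no comparable precedent, a small step is expected in this assay, likely not beyond the scatter, in either direction. Compound 4 is therefore estimated at 60 nM, with a range of 20 nM to 180 nM, meaning an expected 1.7-fold higher number from compound 2 to compound 4 (0.22 log units; within the scatter).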

Compound 4, half-maximal inhibitory concentration: 23.2 nM
Compound 4: middle estimate off by 2.6-fold (0.41 log units), on the high side; measured number inside the range.
By their numbers in this assay, from the lowest: compounds 4 and 2 (each within the scatter of the next); then compound 3; then compound 1.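

In this assay the aryl position on the fused ring accepts this exchange: 3-methylphenyl in place of 4-methoxyphenyl gives a 1.6-fold lower number from compound 2 to compound 4 (0.19 log units; within the scatter) and leaves compound 2 and compound 4 within the scatter of each other. In this pair, the hydrogen-bond acceptor counted on the leaving group is absent from the entering group without a step beyond the scatter. No measured evidence accounts for this result.

Group identity and ring position change together here, so neither can be read alone. Going by these compounds, how an amine or a carboxylic acid on this phenyl ring would read remains open.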